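Methyl for trifluoromethyl on the core of compound 2

The compounds below may be only part of what the source reports. "The series", "measured", "known", "first", "only" and "open" are said of these compounds alone.

Three members of the series have numbers in a functional assay for antagonist activity at thyroid hormone receptor alpha (Homo sapiens), read by fluorescence polarization; on this read-out higher numbers stand for weaker inhibition and lower numbers for stronger inhibition. Compound 1 `CN(Cc1cccc(F)c1)C(=O)c1sc(-c2ccc(S(C)(=O)=O)c([N+](=O)[O-])c2)nc1C(F)(F)F` gives 1000 nM, compound 3 `CN(Cc1ccccc1)C(=O)c1sc(-c2ccc(S(C)(=O)=O)c([N+](=O)[O-])c2)nc1C(F)(F)F` gives 460 nM, and compound 2 `CC1CCN(C(=O)c2sc(-c3ccc(S(C)(=O)=O)c([N+](=O)[O-])c3)nc2C(F)(F)F)CC1` gives 190 nM, the lowest of the three, so the strongest inhibition seen so far. The steps among them all sit at the amide side: a 5.3-fold lower number from compound 1 to compound 2 (0.72 log units; beyond the scatter), a 2.2-fold lower number from compound 1 to compound 3 (0.34 log units; beyond the scatter) and a 2.4-fold higher number from compound 2 to compound 3 (0.38 log units; beyond the scatter).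

Compound 4 `Cc1nc(-c2ccc(S(C)(=O)=O)c([N+](=O)[O-])c2)sc1C(=O)N1CCC(C)CC1` changes a different place, (methyl in place of trifluoromethyl on an aromatic carbon), on an aromatic carbon of the five-membered aromatic ring with one nitrogen and one sulfur. For the measured compounds named here, no measured step touches this position; the measured steps describe only the amide substituent and the fluoro on the benzyl, and none of them transfers to this change. The expectation for this assay therefore rests on the shared core alone and is held close to compound 2, with wide uncertainty: the step of a 1.8-fold higher number from compound 2 to compound 4 (0.27 log units; within the scatter) is expected to be modest or within the scatter. Compound 4 is estimated at 350 nM, in the range 120 nM to 1100 nM.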

Compound 4, half-maximal inhibitory concentration: 5600 nM
Estimate against measurement, compound 4: 16-fold (1.20 log units) below; measured number outside the range, above it.
By their numbers in this assay, from the lowest: compound 2; then compound 3; then compound 1; then compound 4.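

Replacing trifluoromethyl with methyl on this aromatic carbon gives a 29-fold higher number from compound 2 to compound 4 (1.47 log units; beyond the scatter) in this assay, the first measured sign that this position of the shared core strongly affects the read-out. This single change outweighs the largest step seen at the amide side, a 5.3-fold lower number from compound 1 to compound 2 (0.72 log units; beyond the scatter), so trifluoromethyl here cannot be treated as a neutral part of the core. The compounds shown offer no measurement that accounts for the loss, only its size.

On these data alone, it remains open whether the result is particular to methyl or whether ethyl, chloro or a nitrile on the same carbon would give numbers closer to that of compound 2. Also open is whether the step carries over to the benzyl(methyl)amino amide of compound 3, as this change is shown only with the 4-methylpiperidin-1-yl amide.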